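From a Trifluoromethyl Ketone Back to a Pyridine Ester

The source may hold more compounds than are shown below. What is called first, only, known or untested is meant among the compounds shown, and "the series" means these compounds.

Compound 1, `COC(=O)c1ccc(-c2cnc(C(=O)CCc3ccc(-c4ccccc4)cc3)o2)nc1`: 2.2 nM
Compound 2, `N#Cc1cccc(-c2cnc(C(=O)CCc3ccc(-c4ccccc4)cc3)o2)n1`: 2.9 nM
Compound 3, `O=C(CCc1ccc(-c2ccccc2)cc1)c1ncc(C(=O)C(F)(F)F)o1`: 8 nM

All three compounds share the same core and were tested in an assay for inhibition of Fatty-acid amide hydrolase 1 (Rattus norvegicus); on this read-out lower numbers stand for stronger inhibition and higher numbers for weaker inhibition. Compound 3 gives the highest number of the three in this assay; the distance to its nearest neighbour is a 2.8-fold higher number from compound 2 to compound 3 (0.44 log units; beyond the scatter) and to the furthest a 3.6-fold higher number from compound 1 to compound 3 (0.56 log units; beyond the scatter). The two pyridine-bearing compounds sit close together: a 1.3-fold higher number from compound 1 to compound 2 (0.12 log units; within the scatter).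

Compound 4, `COC(=O)c1cccc(-c2cnc(C(=O)CCc3ccc(-c4ccccc4)cc3)o2)n1`, is not yet measured. It differs from compound 3 in one place: 6-(methoxycarbonyl)pyridin-2-yl in place of (trifluoromethyl)carbonyl on an aromatic carbon. Two of the measured steps bear on this change, since each runs from a pyridine group on the same aromatic carbon to the trifluoromethyl ketone: a 3.6-fold higher number from compound 1 to compound 3 (0.56 log units; beyond the scatter) and a 2.8-fold higher number from compound 2 to compound 3 (0.44 log units; beyond the scatter). Compound 4 moves in the opposite direction, back to a pyridine carrying a small substituent, and the two known pyridines differ only within the scatter. For compound 4 a modest step toward a lower number is therefore expected: a 2.7-fold lower number from compound 3 to compound 4 (0.43 log units; beyond the scatter). In this assay compound 4 is estimated at 3 nM, with a likely range from 1.2 nM to 8 nM.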

Compound 4, inhibition constant: 1.2 nM
Compound 4: the middle estimate sits 2.5-fold (0.40 log units) above what was measured; low and high end bracket the measured number.
By their numbers in this assay, from the lowest: compounds 4, 1 and 2 (each within the scatter of the next, the first and the last beyond it); then compound 3.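

In this assay, 6-(methoxycarbonyl)pyridin-2-yl in place of (trifluoromethyl)carbonyl gives a 6.7-fold lower number from compound 3 to compound 4 (0.82 log units; beyond the scatter), so a third pyridine group on this aromatic carbon, next to the ring oxygen, also gives a lower number than the trifluoromethyl ketone. The new compound also separates the substituent from its location on the pyridine, which compound 1 and compound 2 could not do, as they differ in both. With the location kept, methoxycarbonyl in place of cyano gives a 2.4-fold lower number from compound 2 to compound 4 (0.38 log units; beyond the scatter), a step beyond the scatter, whereas with the ester kept, the change from 5-(methoxycarbonyl)pyridin-2-yl to 6-(methoxycarbonyl)pyridin-2-yl gives a 1.8-fold lower number from compound 1 to compound 4 (0.26 log units; within the scatter), a step within the scatter that shows no clear effect of location.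

From the compounds shown here alone, how a carboxylic acid or a primary amide in place of the methoxycarbonyl on this pyridine would compare remains open. The data shown offer no measurement that explains any of these differences.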